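This account rests on a few compounds, and the source may have more. Where it says the series, first, only, none or still open, it means among the compounds named here.

In a functional assay on KBVIN cells (Homo sapiens) for antiproliferative activity, read by sulforhodamine B assay, with a stated time of 3 days (on this read-out higher numbers stand for an effect only at larger amounts of compound and lower numbers for an effect already at smaller amounts), the measured compounds are:
- compound 1 `CCCc1ccc(-c2cc(=O)c3c(o2)C(CC)(CC)C(=O)C(CC)=C3O)cc1` gives 12.2 uM
- compound 2 `CCC1=C(O)c2c(oc(-c3ccc(CBr)cc3)cc2=O)C(CC)(CC)C1=O` gives 27.9 uM
- compound 3 `CCC1=C(O)c2c(oc(-c3ccc(COC)cc3)cc2=O)C(CC)(CC)C1=O` gives 3.4 uM

Compound 3 has the lowest number of the three. The move to compound 4 `CCC1=C(O)c2c(oc(-c3ccccc3C)cc2=O)C(CC)(CC)C1=O` is 2-methylphenyl in place of 4-(methoxymethyl)phenyl on an aromatic carbon and puts 2-methylphenyl in place of 4-(methoxymethyl)phenyl on an aromatic carbon. Within the data shown here, no measured step makes this whole exchange, so the evidence is indirect. Both a 3.6-fold lower number from compound 1 to compound 3 (0.55 log units; beyond the scatter) and an 8.2-fold lower number from compound 2 to compound 3 (0.91 log units; beyond the scatter) end at the methoxy compound with a lower number, while a 2.3-fold higher number from compound 1 to compound 2 (0.36 log units; beyond the scatter) separates the two compounds without methoxy. Compound 4 also has no methoxy, so a modest rise is expected, about the size of the step from compound 1 to compound 3 reversed. The expected step is a 2.9-fold higher number from compound 3 to compound 4 (0.47 log units; beyond the scatter) and remains an estimate. Expected for compound 4 is 10 uM (estimated range 3.5 uM to 30 uM).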

Compound 4, concentration for half-maximal effect: 2.41 uM
Compound 4: the middle estimate sits 4.1-fold (0.62 log units) above what was measured; measured number below the stated range.
By their numbers in this assay, from the lowest: compounds 4 and 3 (each within the scatter of the next); then compound 1; then compound 2.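

Methoxy is not needed for a low number at this position: 2-methylphenyl in place of 4-(methoxymethyl)phenyl gives a 1.4-fold lower number from compound 3 to compound 4 (0.15 log units; within the scatter) and leaves compound 3 and compound 4 unordered. The same group gives a 12-fold lower number from compound 2 to compound 4 (1.06 log units; beyond the scatter) against 4-(bromomethyl)phenyl and a 5.1-fold lower number from compound 1 to compound 4 (0.70 log units; beyond the scatter) against 4-propylphenyl, so this position tolerates a group without methoxy. Nothing at hand explains these differences.

Going by these compounds, whether the methyl group or its place on the ring matters remains open. So does what 4-methylphenyl, unsubstituted phenyl or an aminomethyl group would give here.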